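Expected effect of the isopropylamino chain in compound 4

The source may hold more compounds than are shown below. What is called first, only, known or untested is meant among the compounds shown, and "the series" means these compounds.

In a functional assay on the whole organism for inhibition, with Mus musculus as the target (on this read-out higher numbers stand for an effect only at larger amounts of compound and lower numbers for an effect already at smaller amounts), compound 1 `CCNC(=O)Nc1cccc2c1CN(C)CC2c1ccccc1` gives 80 mg/kg, compound 2 `CCOC(=O)Nc1cccc2c1CN(C)CC2c1ccccc1` gives 3.2 mg/kg and compound 3 `CCNCC(=O)Nc1cccc2c1CN(C)CC2c1ccccc1` gives 47 mg/kg. The nearest step to this last value is a 1.7-fold lower number from compound 1 to compound 3 (0.23 log units; within the scatter), and the furthest is a 15-fold higher number from compound 2 to compound 3 (1.17 log units; beyond the scatter). Compound 4 `CC(C)NCCC(=O)Nc1cccc2c1CN(C)CC2c1ccccc1` carries (isopropylamino)methyl in place of ethylamino on a saturated chain carbon bound to a carbonyl carbon. Among the compounds with values here, no measured step makes this exact change. The closest guide is a 1.7-fold lower number from compound 1 to compound 3 (0.23 log units; within the scatter), which also swaps one nitrogen-bearing group for another. The large steps, such as a 25-fold lower number from compound 1 to compound 2 (1.40 log units; beyond the scatter), involve the ethoxy group, which is absent here. The expected result in this assay is therefore no shift beyond the scatter, namely a 1.2-fold lower number from compound 3 to compound 4 (0.07 log units; within the scatter). The estimate for compound 4 is 40 mg/kg, with an expected range from 15 mg/kg to 100 mg/kg.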

Compound 4, dose for half-maximal effect: 150 mg/kg
Estimate against measurement, compound 4: 3.8-fold (0.57 log units) below; measured number outside the range, above it.
By their numbers in this assay, from the lowest: compound 2; then compounds 3, 1 and 4 (each within the scatter of the next, the first and the last beyond it).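

In this assay, this position proves sensitive to a change from one amine chain to another: going from (ethylamino)methyl to 2-(isopropylamino)ethyl gives a 3.2-fold higher number from compound 3 to compound 4 (0.50 log units; beyond the scatter) on the saturated chain carbon's side of the carbonyl carbon. Against the ethylamino group the new chain shows a 1.9-fold higher number from compound 1 to compound 4 (0.27 log units; within the scatter) and against ethoxy it shows a 47-fold higher number from compound 2 to compound 4 (1.67 log units; beyond the scatter), so ethoxy remains the only group here with a low number. Nothing measured explains this shift.

The isopropyl group and the longer chain change together, so their contributions cannot be separated. Going by these compounds, how a 2-(ethylamino)ethyl chain or a piperidine at the chain end would read remains open.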